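Replacing azido with amino after a large chloro step

The source may report more compounds than this note shows. Statements on the series, on what has been measured and on what is new or still open speak of the compounds shown alone.

In a functional assay on L1210 cells (Mus musculus) for inhibition (a lower number here means a stronger inhibitor, a higher number a weaker inhibitor), two compounds that share one core have been measured. Compound 1 `O=c1[nH]c(=O)n(C2O[C@H](CCl)[C@@H](O)[C@H]2O)cc1F`, which carries chloro on a saturated chain carbon bound to a saturated ring carbon, gives 3400 nM. Compound 2 `[N-]=[N+]=NC[C@H]1OC(n2cc(F)c(=O)[nH]c2=O)[C@H](O)[C@@H]1O`, with azido at that place, gives 170000 nM, the higher of the two numbers, which makes it the weaker inhibitor of the pair. Compound 3 `NC[C@H]1OC(n2cc(F)c(=O)[nH]c2=O)[C@H](O)[C@@H]1O` has not yet been measured in this assay. It has amino in place of the azido of compound 2: amino in place of azido on a saturated chain carbon bound to a saturated ring carbon. Within the data shown here, only one measured step bears on this change, namely a 50-fold higher number from compound 1 to compound 2 (1.70 log units; beyond the scatter). That step is large and occurs at the same place, so the group there can clearly move the number a long way. Among the measured compounds shown here, no compound with amino has been measured, so the direction rests on thin evidence. A moderate move towards a lower number is expected, smaller than the chloro step. The estimate amounts to a 2.8-fold lower number from compound 2 to compound 3 (0.45 log units; beyond the scatter), and this expected step remains uncertain. For compound 3 the estimated value is 60000 nM, with an expected range of 8000 nM to 300000 nM.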

Compound 3, half-maximal inhibitory concentration: 8700 nM
Beside the measured number, compound 3's estimate is 6.9-fold (0.84 log units) above it; low and high end bracket the measured number.
By their numbers in this assay, from the lowest: compound 1; then compound 3; then compound 2.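

In this assay the change of azido to amino on a saturated chain carbon bound to a saturated ring carbon gives a 20-fold lower number from compound 2 to compound 3 (1.29 log units; beyond the scatter) on the shared core, so leaving chloro at this place does not in itself cost much, and the high number of compound 2 goes with azido in particular. Amino does not fully match chloro, since the comparison shows a 2.6-fold higher number from compound 1 to compound 3 (0.41 log units; beyond the scatter) and this modest step still lies beyond the usual scatter. The position therefore separates all three groups, with the numbers rising from chloro through amino to azido, and the gap between amino and chloro is much smaller than the gap between amino and azido.

Nothing shown here accounts for why azido stands so far from the other two groups, as no supporting measurement accompanies these numbers. From the compounds shown here alone, it remains open where a hydroxyl, a fluoro or a longer chain such as aminoethyl would fall at this place, and whether any group there could give a lower number than chloro does.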